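Trimming a Protected Amine Chain Down to a Hydroxy

A few compounds are considered here, and "the series" means these few. Any claim that something is new, unique, unknown or untested is made for them only; others in the source may bear on it.

Compound 1 `CC(C)(C)OC(=O)NCCCNC(=O)CN1CN(c2ccccc2)C2(CCN(C(=O)c3ccc(C4CCCCC4)cc3)CC2)C1=O` is measured in an assay on HEK293 cells for displacement of a labelled ligand from NPC1-like intracellular cholesterol transporter 1 (Homo sapiens) (a higher number here means a weaker inhibitor, a lower number a stronger inhibitor), where compound 1 gives 6000 nM. Two companions share its core. Compound 3 `CC(C)(C)OC(=O)NCC1CCN(C(=O)CN2CN(c3ccccc3)C3(CCN(C(=O)c4ccc(C(C)(C)C)cc4)CC3)C2=O)CC1` gives 4200 nM, a number that sits within the usual scatter of that of compound 1, so the two cannot be told apart. Compound 2 `CC(C)(C)c1ccc(C(=O)N2CCC3(CC2)C(=O)N(CC(=O)NCCO)CN3c2ccccc2)cc1` gives 1000 nM, and that gap to compound 1 lies beyond the scatter. Compound 1 thus stands at the upper edge of the three numbers, with compound 3 beside it and compound 2 clearly lower.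

The new compound 4 `O=C(CN1CN(c2ccccc2)C2(CCN(C(=O)c3ccc(C4CCCCC4)cc3)CC2)C1=O)NCO` differs from compound 1 in one place: hydroxy in place of 2-((tert-butoxycarbonyl)amino)ethyl on a saturated chain carbon bound to an amide-type nitrogen. The 2-((tert-butoxycarbonyl)amino)ethyl leaves, the hydroxy enters, and the rest of the molecule is untouched.

Within the data shown here, no measured pair shows this exact change alone. Among the measured compounds shown here, compound 2 also carries a hydroxy rather than a tert-butoxycarbonyl-protected chain, but it differs from compound 1 in more than one place, so its value shows only that all of its changes together gave a lower number. The step from compound 1 to compound 4 is therefore expected to be modest and downward, close to the scatter, as a 2.0-fold lower number from compound 1 to compound 4 (0.30 log units; within the scatter). Compound 4 is estimated at 3000 nM in this assay, with a range from 1200 nM to 8000 nM.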

Compound 4, half-maximal inhibitory concentration: 8300 nM
Compound 4: the middle estimate sits 2.8-fold (0.44 log units) below what was measured; measured number above the stated range.
By their numbers in this assay, from the lowest: compound 2; then compounds 3, 1 and 4 (each within the scatter of the next).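

In this assay, among these compounds, this is the first comparison in which only one place differs, and it gives a 1.4-fold higher number from compound 1 to compound 4 (0.14 log units; within the scatter). A 2-((tert-butoxycarbonyl)amino)ethyl of 10 heavy atoms can thus give way to a hydroxy of 1 heavy atom on this saturated chain carbon bound to an amide-type nitrogen, and the two numbers still cannot be told apart, so on this core the large protected chain is not required for a number at this level. Nothing available here accounts for that result, so it stands as an observation about these two compounds alone.

The compounds shown leave open whether a free amine or a carboxylic acid in this place would give a number that differs from that of compound 1 by more than the scatter. They also leave open how a longer chain ending in a hydroxy would behave on the same core, and so whether the number responds to this position at all.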